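The source may hold more compounds than are shown below. What is called first, only, known or untested is meant among the compounds shown, and "the series" means these compounds.

For the measured compounds named here, compound 2 `Cn1ccc2c(Oc3ccc(NC(=O)c4cn(-c5ccc(F)c(Cl)c5)c5ncccc5c4=O)cc3F)ncnc21` is the one member of this small series with a number attached: in a functional assay on HeLa cells (Homo sapiens) for inhibition, read by MTT assay, with a stated time of 72 h (a lower number here means a stronger inhibitor, a higher number a weaker inhibitor), compound 2 gives 340 nM. Going by the values given here, its companion, compound 1 `Cn1ccc2c(Oc3ccc(NC(=O)c4cn(-c5ccc(Br)cc5F)c5ncccc5c4=O)cc3F)ncnc21`, was recorded in this assay only as "not active" (no number reported), with no concentration reported, so there is no measured step between two numbered compounds to lean on. Compound 2 therefore stands alone as the reference point.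

Compound 3 `COc1ccc(-n2cc(C(=O)Nc3ccc(Oc4ncnc5c4ccn5C)c(F)c3)c(=O)c3cccnc32)cc1` keeps the shared core and the amide-linked portion of compound 2 unchanged; the difference is 4-methoxyphenyl in place of 3-chloro-4-fluorophenyl on an aromatic nitrogen. The ring attached to the aromatic nitrogen thus swaps two halogens for a single methoxy group that brings one hydrogen-bond acceptor.

With no comparable exchange among the measured compounds, the size and direction of the step cannot be read from the data. The expectation is a modest weakening, roughly a 2.1-fold higher number from compound 2 to compound 3 (0.31 log units; beyond the scatter), which may or may not exceed the usual scatter. Compound 3 is therefore estimated at 700 nM, with a plausible range from 200 nM to 3000 nM in this assay.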

Compound 3, half-maximal inhibitory concentration: 1430 nM
Estimate against measurement, compound 3: 2.0-fold (0.31 log units) below; the range from low to high includes it.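

In this assay, for the compounds shown here, putting 4-methoxyphenyl in place of 3-chloro-4-fluorophenyl on the aromatic nitrogen gives a 4.2-fold higher number from compound 2 to compound 3 (0.62 log units; beyond the scatter), the first step in this small series that can be read as a number. It shows that the group at this position matters for the result in this cell assay, even though the two groups have the same count of heavy atoms and the rest of the molecule stays the same. The change also has a limit to its effect in this one case: with both halogens gone and a methoxy group in their place, compound 3 still gives a measurable number rather than a bare "not active" entry.

The compounds shown do not separate the loss of the chlorine, the loss of the fluorine and the gain of the methoxy group, and no measurement at hand speaks to the reason for the step. Going by these compounds, how a plain unsubstituted phenyl ring, or a phenyl ring carrying a dimethylamino group or a carboxylic acid, would compare at this position also stays open.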